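Replacing Chloro with Methyl on the Aryl Ring

The source may report more compounds than this note shows. Statements on the series, on what has been measured and on what is new or still open speak of the compounds shown alone.

Going by the values given here, in a functional assay on the whole organism with Mus musculus as the target (on this read-out higher numbers stand for an effect only at larger amounts of compound and lower numbers for an effect already at smaller amounts), compound 3 `OC1CCN(c2ccc(-c3ccc(Cl)cc3Cl)nn2)CC1` gives 8.5 mg/kg, the lowest of the three numbers measured so far. Compound 1 `OC1CCN(c2ccc(-c3ccccc3)nn2)CC1` gives 83 mg/kg and compound 2 `OC1CCN(c2ccc(-c3ccccc3Cl)nn2)CC1` gives 38 mg/kg. The two steps between these compounds each put a chloro in place of hydrogen on an aromatic carbon: a 2.2-fold lower number from compound 1 to compound 2 (0.34 log units; beyond the scatter) and a 4.5-fold lower number from compound 2 to compound 3 (0.65 log units; beyond the scatter). Compound 4 `Cc1ccc(-c2ccc(N3CCC(O)CC3)nn2)c(Cl)c1` differs from compound 3 by methyl in place of chloro on an aromatic carbon. Among the compounds with values here, no measured step exchanges a chloro for a methyl, so the earlier steps bear on this one only loosely: they show that the number fell as each chloro came in, and compound 4 keeps one chloro while a methyl now sits where the second one was. Within the data shown here, with no direct precedent, a step of modest size at most is expected, more likely toward a higher number than a lower one. Compound 4 is expected to give about 13 mg/kg, with a range from 5 mg/kg to 35 mg/kg. That estimate corresponds to a 1.5-fold higher number from compound 3 to compound 4 (0.18 log units; within the scatter).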

Compound 4, dose for half-maximal effect: 17 mg/kg
The estimate for compound 4 lay 1.3-fold (0.12 log units) below the measured number, and the stated range covers the measured number.
By their numbers in this assay, from the lowest: compounds 3 and 4 (each within the scatter of the next); then compound 2; then compound 1.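

At this position, para to a large group and meta to a chloro group, methyl can stand in for chloro: this assay shows a 2.0-fold higher number from compound 3 to compound 4 (0.30 log units; within the scatter), so the two groups cannot be told apart here. Methyl also counts as a real change from hydrogen, with a 2.2-fold lower number from compound 2 to compound 4 (0.35 log units; beyond the scatter), which shows that the drop in the number at this position is not tied to chloro alone. No measurement among those shown accounts for this shared behaviour of the two groups.

On these data alone, whether a fluoro, a methoxy, a longer chain such as propyl, or an amine at this position would keep the number close to those of compound 3 and compound 4 remains open. Also open, as far as these compounds go, is whether methyl would give a similar step on a ring without the other chloro.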